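This account rests on a few compounds, and the source may have more. Where it says the series, first, only, none or still open, it means among the compounds named here.

Compound 3 `COc1cc2c(Oc3ccc(NC(=O)N/N=C/c4ccc(N(C)C)cc4)cc3F)ccnc2cc1OCCCN1CCCCC1` shares its core with compound 1 `COc1cc2c(Oc3ccc(NC(=O)N/N=C/c4ccc(C(F)(F)F)cc4)cc3F)ccnc2cc1OCCCN1CCCCC1` and compound 2 `COc1cc2c(Oc3ccc(NC(=O)N/N=C/c4ccc(F)cc4Cl)cc3F)ccnc2cc1OCCCN1CCCCC1`, differing from them only in the aromatic ring that hangs from the carbon with a double bond to nitrogen. In a functional assay on A549 cells (Homo sapiens) for cytotoxicity, read by MTT assay, with a stated time of 72 h (a lower number here means a stronger inhibitor, a higher number a weaker inhibitor), compound 1 gives 660 nM, and in this assay compound 2 gives 130 nM, so that a 5.1-fold lower number from compound 1 to compound 2 (0.71 log units; beyond the scatter). For compound 3 this assay reports "not determined" (no result reported), so no number stands for it, and its standing among these compounds is therefore unknown.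

Compound 4 `COc1cc2c(Oc3ccc(NC(=O)N/N=C/c4ccc(O)cc4)cc3F)ccnc2cc1OCCCN1CCCCC1` arises from compound 3 by one change: hydroxy in place of dimethylamino on an aromatic carbon. Among the measured compounds shown here, no measured step speaks to this exchange directly. For the measured compounds named here, the one step that was measured, a 5.1-fold lower number from compound 1 to compound 2 (0.71 log units; beyond the scatter), sits on the same ring but swaps a different pair of groups, and it shows only that a change in this ring can move the number by a modest amount. There is no number for compound 3 from which to count a step, and nothing here tells whether a hydroxy group in place of dimethylamino pushes the number up or down. The expectation for compound 4 in this assay therefore rests on the span of compound 1 and compound 2 alone, with a wide band: compound 4 is estimated at 400 nM, between 90 nM and 1800 nM.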

Compound 4, half-maximal inhibitory concentration: 780 nM
Compound 4: the middle estimate sits 2.0-fold (0.29 log units) below what was measured; the measured number falls inside the stated range.
By their numbers in this assay, from the lowest: compound 2; then compounds 1 and 4 (each within the scatter of the next).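

In this assay, the 4-hydroxyphenyl and 4-(trifluoromethyl)phenyl rings are not told apart (a 1.2-fold higher number from compound 1 to compound 4 (0.07 log units; within the scatter)), so two different groups on this aromatic carbon give numbers within the scatter of each other. The 2-chloro-4-fluorophenyl ring of compound 2 now stands apart from both of the other measured rings, as the step to the hydroxy compound (a 6.0-fold higher number from compound 2 to compound 4 (0.78 log units; beyond the scatter)) is beyond the scatter, as is the earlier step (a 5.1-fold lower number from compound 1 to compound 2 (0.71 log units; beyond the scatter)). Compound 3 has no number, so any step from its dimethylamino group to hydroxy cannot be read, and the part of the result that concerns this exchange stays empty.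

Nothing measured here gives a reason for these numbers. The compounds shown leave open whether the lower number of compound 2 depends on its chlorine, its fluorine or the two together, which a 2-chlorophenyl or a 4-fluorophenyl ring would separate, and how a carboxylic acid or a primary amine on this carbon would compare.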